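Amide substituent changes on a shared core in 5-HT1F binding

The source may hold more compounds than are shown below. What is called first, only, known or untested is meant among the compounds shown, and "the series" means these compounds.

Measured so far:
compound 1 `CN1CCC(c2c[nH]c3cnc(NC(=O)c4ccc(F)cc4)cc23)CC1`, 13 nM
compound 2 `CCCCCC(=O)Nc1ccc2[nH]cc(C3CCN(C)CC3)c2n1`, 13 nM
compound 3 `Cc1cccc(C(=O)Nc2ccc3[nH]cc(C4CCN(C)CC4)c3n2)c1`, 5.8 nM

In an assay for binding affinity to 5-hydroxytryptamine receptor 1F (Homo sapiens), read by radioligand binding (a higher number here means a weaker inhibitor, a lower number a stronger inhibitor), compound 3 gives 5.8 nM, the lowest of the three numbers; compound 1 and compound 2 both sit higher by the same margin, each beyond the scatter. Compound 3 therefore stands as the tightest binder among the compounds measured here.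

Compound 4 `CN1CCC(c2c[nH]c3ccc(NC(=O)C(C)(C)C)nc23)CC1` has not yet been measured in this assay. It differs from compound 3 in one place: tert-butyl in place of 3-methylphenyl on a carbonyl carbon.

For the measured compounds named here, only one measured step bears on this change. The step of a 2.2-fold lower number from compound 2 to compound 3 (0.35 log units; beyond the scatter) shows that replacing an open alkyl chain on the carbonyl carbon with the aromatic 3-methylphenyl brought the number down modestly. Compound 4 moves in the reverse sense, from the aromatic group back to an alkyl group, though a branched and shorter one than the pentyl of compound 2. On that basis the expected step of a 2.6-fold higher number from compound 3 to compound 4 (0.41 log units; beyond the scatter) is a modest rise in the number, roughly undoing the gain seen in compound 3, though a tert-butyl is not a pentyl and the size of the step is uncertain. Compound 4 is therefore estimated at 15 nM, with a range from 5 nM to 45 nM.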

Compound 4, inhibition constant: 62 nM
Compound 4: the middle estimate sits 4.1-fold (0.62 log units) below what was measured; measured number above the stated range.
By their numbers in this assay, from the lowest: compound 3; then compounds 1 and 2 (each within the scatter of the next); then compound 4.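

For the compounds shown here, on the shared core, the group on the carbonyl carbon matters more in this assay than the earlier compounds showed: the large step (an 11-fold higher number from compound 3 to compound 4 (1.03 log units; beyond the scatter)) far exceeds the modest one seen before (a 2.2-fold lower number from compound 2 to compound 3 (0.35 log units; beyond the scatter)). The change is also not simply a swap of an aromatic group for an alkyl group, since the two alkyl groups differ from each other (a 4.8-fold higher number from compound 2 to compound 4 (0.68 log units; beyond the scatter)), placing the three groups in the order 3-methylphenyl, pentyl, tert-butyl, from the lowest number to the highest. Nothing available here accounts for why tert-butyl gives the highest number of these three.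

The compounds shown leave open whether the gain with 3-methylphenyl comes from the ring itself or from its methyl, a question that an unsubstituted phenyl in the same place would address. They also leave open whether the difference between pentyl and tert-butyl follows from chain branching or chain length, which a straight butyl or a cyclohexyl on the carbonyl carbon could help separate.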